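Cyclohexyl to phenethyl on the boronate side chain

The source may hold more compounds than are shown below. What is called first, only, known or untested is meant among the compounds shown, and "the series" means these compounds.

In an assay on isolated protein for inhibition of Lon protease homolog, mitochondrial (Homo sapiens), read by HTRF, with a stated time of 50 min, in the presence of a further agent that is not named here (a lower number here means a stronger inhibitor, a higher number a weaker inhibitor), three compounds have been measured:
compound 1, `CC[C@@H](NC(=O)c1cnccn1)C(=O)N[C@@H](CC(C)C)B(O)O`, gives 408 nM
compound 2, `CC(C)C[C@H](NC(=O)C(C)(C)NC(=O)c1cnccn1)B(O)O`, gives 6200 nM
compound 3, `CCC[C@@H](NC(=O)c1cnccn1)C(=O)N[C@@H](CC1CCCCC1)B(O)O`, gives 136 nM

Compound 3 has the lowest number of the three, with compound 1 nearest and compound 2 furthest. Compound 4, `CCC[C@@H](NC(=O)c1cnccn1)C(=O)N[C@@H](CCCc1ccccc1)B(O)O`, differs from compound 3 in one place: phenethyl in place of cyclohexyl on a saturated chain carbon, two bonds along the chain from an amide-type nitrogen and a boron atom. Going by the values given here, no measured pair shows this change, so no step can be read from the data. The two groups are of similar size, and the expectation is a step of a 1.5-fold higher number from compound 3 to compound 4 (0.17 log units; within the scatter) in this assay, small and likely within the scatter. For compound 4 the estimate in this assay is 200 nM, within a range from 70 nM to 600 nM.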

Compound 4, half-maximal inhibitory concentration: 17 nM
Estimate against measurement, compound 4: 12-fold (1.07 log units) above; the measured number lies below the stated range.
By their numbers in this assay, from the lowest: compound 4; then compound 3; then compound 1; then compound 2.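

In this assay, phenethyl in place of cyclohexyl gave an 8.0-fold lower number from compound 3 to compound 4 (0.90 log units; beyond the scatter), a step beyond the scatter, showing that this saturated chain carbon responds to the group it carries. The earlier compounds shown here held no pair differing only here, and the two groups' similar size did not make the change a quiet one. Nothing available explains the gain.

The change alters ring and chain together, so the compounds shown do not separate the aromatic ring from the added carbons. A cyclohexylethyl or a benzyl group would bear on that question, and neither stands among them.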